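The source may report more compounds than this note shows. Statements on the series, on what has been measured and on what is new or still open speak of the compounds shown alone.

The account follows compound 3, `O=C(CN1CN(c2ccccc2)C2(CCN(C(=O)c3ccc(C4CCCCC4)cc3)CC2)C1=O)N1CCCCC1`, which in an assay on HEK293 cells for displacement of a labelled ligand from NPC1-like intracellular cholesterol transporter 1 (Homo sapiens) (a lower number here means a stronger inhibitor, a higher number a weaker inhibitor), gives 1100 nM. Among the three compounds measured in this assay, compound 3 holds the second-highest number. Its nearest neighbour is compound 1, `CCOC(=O)C1CCN(C(=O)CN2CN(c3ccccc3)C3(CCN(C(=O)c4ccc(C5CCCCC5)cc4)CC3)C2=O)CC1`, which gives 900 nM; the step of a 1.2-fold higher number from compound 1 to compound 3 (0.09 log units; within the scatter) lies within the scatter, so the two cannot be told apart. Compound 2, `CCC1CCCN(C(=O)CN2CN(c3ccccc3)C3(CCN(C(=O)c4ccc(C5CCCCC5)cc4)CC3)C2=O)C1`, gives 2600 nM, and the step of a 2.4-fold lower number from compound 2 to compound 3 (0.37 log units; beyond the scatter) is beyond the scatter.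

The next compound, compound 4, `CC1CCCN(C(=O)CN2CN(c3ccccc3)C3(CCN(C(=O)c4ccc(C5CCCCC5)cc4)CC3)C2=O)C1`, differs from compound 3 by methyl in place of hydrogen on a saturated ring carbon. The measured step that bears most directly on this change is a 2.4-fold lower number from compound 2 to compound 3 (0.37 log units; beyond the scatter), where taking the ethyl off that ring carbon gave a lower number. The step of a 2.9-fold higher number from compound 1 to compound 2 (0.46 log units; beyond the scatter) also places the ethyl-bearing compound at the weak end of the three. A methyl is a shorter chain than an ethyl, so a modest rise in the number, smaller than the ethyl step and possibly not clearing the scatter, is the expectation.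

On this basis compound 4 is expected to give 1700 nM, with a range from 900 nM to 3200 nM. The expected step is therefore a 1.5-fold higher number from compound 3 to compound 4 (0.19 log units; within the scatter).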

Compound 4, half-maximal inhibitory concentration: 3600 nM
Compound 4: the middle estimate sits 2.1-fold (0.33 log units) below what was measured; the whole stated range lies below it.
By their numbers in this assay, from the lowest: compounds 1 and 3 (each within the scatter of the next); then compounds 2 and 4 (each within the scatter of the next).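

The new result shows that the rise in the number at this ring carbon does not need a chain as long as ethyl: in this assay, methyl in place of hydrogen, two ring bonds from the ring nitrogen, already brings a 3.3-fold higher number from compound 3 to compound 4 (0.51 log units; beyond the scatter) on its own. The earlier compounds shown here showed the effect only for ethyl, whereas a 1.4-fold higher number from compound 2 to compound 4 (0.14 log units; within the scatter) lies within the scatter, so the 3-methylpiperidin-1-yl and 3-ethylpiperidin-1-yl groups cannot be told apart here. The 3-methylpiperidin-1-yl group also stands clear of the 4-(ethoxycarbonyl)piperidin-1-yl group, with a 4.0-fold higher number from compound 1 to compound 4 (0.60 log units; beyond the scatter) as the step between them.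

The compounds shown leave open whether a 4-methylpiperidin-1-yl or 4-ethylpiperidin-1-yl group would stay level with compounds 1 and 3 or match compounds 2 and 4. They also leave open whether a hydroxyl or a carboxylic acid on the ring carbon that bears the methyl in compound 4 would give a similar number. Nothing available explains why this single methyl changes the number in this assay.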